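Working notes: expected solubility of compound 4

The compounds below may be only part of what the source reports. "The series", "measured", "known", "first", "only" and "open" are said of these compounds alone.

Compound 3 `Cn1cc(-c2cnc3[nH]cc(-c4ccc(O)cc4)c3c2)cn1` is known in a physicochemical assay for solubility, read by LC-MS, in phosphate buffer, measured as thermodynamic solubility, with a stated time of 24 h, at pH 7.4 (a lower number here means a less soluble compound, a higher number a more soluble compound), only as a limit; in that assay compound 3 gives < 3000 nM. This is the limit described at the limit of < 3000 nM in this assay, at which 1 of the 3 values shown sits. For comparison, compound 1 `Cc1ccc(-c2c[nH]c3ncc(-c4cnn(C)c4)cc23)cc1` gives 7000 nM in this assay, and compound 2 `Cn1cc(-c2cnc3[nH]cc(-c4cccc(F)c4)c3c2)cn1` gives 3000 nM. The step of a 2.3-fold lower number from compound 1 to compound 2 (0.37 log units; beyond the scatter) is modest, the step of an at least 2.3-fold lower number from compound 1 to compound 3 (0.36 log units; beyond the scatter) is at least modest, and the step of a number no higher from compound 2 to compound 3 (the limit leaves the size open) has no readable size, compound 3 standing at a limit. All three measured compounds therefore sit within a narrow band at the low end of the scale.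

Compound 4 `Cn1cc(-c2cnc3[nH]cc(-c4cccnc4)c3c2)cn1` differs from compound 3 by pyridin-3-yl in place of 4-hydroxyphenyl on an aromatic carbon. Within the data shown here, no measured step exchanges the six-membered aromatic ring of carbon only for a six-membered aromatic ring with one hetero atom, so the two ring swaps starting from compound 1 are the only guide, and both moved the number only modestly downward. With compound 3 fixed only by a limit, the direction of the step is open in the data; the working expectation is a number somewhat above that limit. Compound 4 is estimated at 6000 nM, with a range of 2000 nM to 20000 nM, which amounts to an expected step of an at least 2.0-fold higher number from compound 3 to compound 4 (0.30 log units; that floor lies within the scatter).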

Compound 4, solubility: 97000 nM
Beside the measured number, compound 4's estimate is 16-fold (1.21 log units) below it, and the stated range ends below it.
By their numbers in this assay, from the lowest: compound 2; then compound 1; then compound 4.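

Pyridin-3-yl, on an aromatic carbon of a five-membered aromatic ring with 1 nitrogen, produces the first large step at this position in this assay: with 3-fluorophenyl leaving, the change is a 32-fold higher number from compound 2 to compound 4 (1.51 log units; beyond the scatter) and with 4-methylphenyl leaving, it is a 14-fold higher number from compound 1 to compound 4 (1.14 log units; beyond the scatter) in the same direction. The earlier compounds shown here, all carrying a six-membered aromatic ring of carbon only here, gave at most a modest readable spread, so this position proves far more responsive than they suggested once that ring gives way to a six-membered aromatic ring with 1 hetero atom. The remaining change, an at least 32-fold higher number from compound 3 to compound 4 (1.50 log units; beyond the scatter) as printed, is a floor and not a size, its starting value being a limit: the limit of < 3000 nM in this assay, at which 1 of the 4 values shown sits.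

The compounds shown leave open whether the large rise belongs to the ring nitrogen itself or to its placement, and a pyridin-4-yl or pyrimidinyl group at the same position would separate the two. Also open, from the compounds shown here alone, is whether an amine or a carboxylic acid on the phenyl ring could reach a similar number without any ring nitrogen.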